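The compounds below may be only part of what the source reports. "The series", "measured", "known", "first", "only" and "open" are said of these compounds alone.

In a functional assay on SW-620 cells (Homo sapiens) for cytotoxicity, read by sulforhodamine B assay, with a stated time of 48 h, tested at 0.1 uM (on this read-out lower numbers stand for a stronger effect and higher numbers for a weaker effect at the one concentration tested), compound 3 `COc1ccc(C(=O)/C=C/c2cc(-c3cc(OC)c(OC)c(OC)c3)n[nH]2)cc1OC` gives 99%. Two related compounds have also been measured in this assay: compound 1 `COc1cc(-c2cc(/C=C/C(=O)c3ccc(Cl)c(Cl)c3)[nH]n2)cc(OC)c1OC` gives 99%, and compound 2 `COc1ccc(-c2cc(/C=C/C(=O)c3cc(OC)c(OC)c(OC)c3)[nH]n2)cc1OC` gives 96%. Compound 3 thus stands level with compound 1, the two together being the highest of the three numbers, while compound 2 lies within the scatter of both. Within the data shown here, the only step measured between single-point changes is no change at the digits printed from compound 1 to compound 3 (within the scatter), which shows that swapping one aryl group for another on the carbonyl side left the read-out unchanged.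

Compound 4 `COc1cc(C(=O)/C=C/c2cc(-c3cc(OC)c(OC)c(OC)c3)n[nH]2)cc(OC)c1OC` differs from compound 3 by methoxy in place of hydrogen on an aromatic carbon. Among the measured compounds shown here, no measured step concerns adding a methoxy group, so nothing directly matching this change is available. For the measured compounds named here, what is available is that all three measured compounds sit close together at the upper end of the scale, and that the one change tried so far produced no movement. A methoxy group is a small addition, and on this evidence the step from compound 3 to compound 4 is expected to be a number 1 percentage points lower from compound 3 to compound 4 (within the scatter), that is, none beyond the scatter. For compound 4 the estimated value is 98%, with an expected range from 90% to 100%.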

Compound 4, a percentage reported as activity, at one concentration (the size of the read-out at that concentration, not a potency): 97%
Compound 4: middle estimate off by 1 percentage points, on the high side, within the range that was stated.
By their numbers in this assay, from the lowest: compounds 2, 4, 1 and 3 (each within the scatter of the next).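

Methoxy in place of hydrogen on an aromatic carbon can now be read twice in this assay, and the two readings fall on different aromatic rings of compound 4. On one ring the step is a number 2 percentage points lower from compound 3 to compound 4 (within the scatter), and on the other it is a number 1 percentage points higher from compound 2 to compound 4 (within the scatter). So this small addition joins the earlier aryl swap as a change that leaves the read-out within the scatter at the one concentration tested, on either ring, and no measurement at hand offers an explanation for this.

Going by these compounds, all four compounds sit close together at the weak end of this scale, so it remains open whether any group at this position could move the number at all, or whether the methoxy group would matter at a higher concentration. An amine, a carboxylic acid or a longer chain in place of the methoxy group could behave quite differently, and the compounds shown say nothing about any of them.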